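Taking the methoxy group off compound 1

A few compounds are considered here, and "the series" means these few. Any claim that something is new, unique, unknown or untested is made for them only; others in the source may bear on it.

Measured so far in a functional assay on EA.hy 926 cells (Homo sapiens) for cytotoxicity, read by MTT assay, with stated times of 24 h and 12 h; on this read-out higher numbers stand for an effect only at larger amounts of compound and lower numbers for an effect already at smaller amounts:
compound 1 `COc1ccc(/C=C/C(=O)O)cc1OC(=O)c1nc(C)c(C)nc1C` with 8800 nM
compound 2 `CCOC(=O)/C=C/c1ccc(OC(=O)c2nc(C)c(C)nc2C)c(O)c1` with 1700 nM
compound 3 `CCOC(=O)/C=C/c1ccc(OC)c(OC(=O)c2nc(C)c(C)nc2C)c1` with 29900 nM

Compound 1 holds the second highest of the three numbers. Compound 3 lies above it and compound 2 below it, both beyond the scatter. The next compound to be read is compound 4 `Cc1nc(C)c(C(=O)Oc2cccc(/C=C/C(=O)O)c2)nc1C` and the change is hydrogen in place of methoxy on an aromatic carbon which puts hydrogen in place of methoxy on an aromatic carbon, para to a 2-carboxyethenyl group.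

For the measured compounds named here, no measured step touches this position. Going by the values given here, the only single-place step available is a 3.4-fold higher number from compound 1 to compound 3 (0.53 log units; beyond the scatter) and it exchanges hydrogen for ethyl elsewhere in the molecule, so it bears on the present change only as a rough guide to size. Compound 2 and compound 3 differ from each other in more than one place, so their values mark only the spread of the series.

Among the compounds with values here, the data therefore give no direction for the step in this assay and a step no larger than a modest one is expected, with little net change as the central guess. Compound 4 is estimated at 8000 nM with an expected range from 2500 nM to 26000 nM in this assay. The expected step is a 1.1-fold lower number from compound 1 to compound 4 (0.04 log units; within the scatter) on this estimate.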

Compound 4, half-maximal effective concentration: 24000 nM
Compound 4: middle estimate off by 3.0-fold (0.48 log units), on the low side; the range from low to high includes it.
By their numbers in this assay, from the lowest: compound 2; then compound 1; then compounds 4 and 3 (each within the scatter of the next).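

In this assay this position now has its first direct reading: a 2.7-fold higher number from compound 1 to compound 4 (0.44 log units; beyond the scatter), so replacing methoxy with hydrogen on the aromatic carbon para to a 2-carboxyethenyl group does not leave the number flat. For the compounds shown here, the position therefore matters on this read-out, with methoxy in compound 1 going along with an effect at smaller amounts of compound than hydrogen in compound 4, a direction that the earlier compounds could not give. No measured property or other supporting data bear on this shift, so the result stands as an observation without an account of its origin.

On these data alone, it remains open whether the same step holds when the 2-carboxyethenyl group carries the ethyl ester of compound 3, as this single pair describes only the free carboxylic acid form. Also open, as far as these compounds go, is how an ethoxy group, a fluorine atom or an amine on this same aromatic carbon would read against methoxy and hydrogen, and so whether the step depends on the particular group placed there.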